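This account rests on a few compounds, and the source may have more. Where it says the series, first, only, none or still open, it means among the compounds named here.

In a functional assay on U-251 cells (Homo sapiens) for inhibition, read by sulforhodamine B assay, with a stated time of 48 h (on this read-out higher numbers stand for weaker inhibition of growth and lower numbers for stronger inhibition of growth), the measured compounds are these.
Compound 1 `CC(C)(C)NCc1c(C(=O)O)nn(-c2ccccc2)c1-c1ccc(F)cc1` gives > 680000 nM, which is a limit of the assay rather than a number.
Compound 2 `CC(C)(C)NCc1c(C(=O)O)nn(-c2ccccc2)c1-c1ccc(Cl)cc1` gives > 652000 nM, likewise a limit.
Compound 3 `CC(C)(C)NCc1c(C(=O)O)nn(-c2ccccc2)c1-c1ccccc1` gives > 716000 nM, also a limit.

Because all three values are limits, the step that the two limits leave unreadable from compound 3 to compound 2, which is chloro in place of hydrogen on an aromatic carbon, has no readable size, and the same holds for a step that the two limits leave unreadable from compound 1 to compound 3 and a step that the two limits leave unreadable from compound 1 to compound 2.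

Compound 4 `CC(C)(C)NCc1c(C(=O)O)nn(-c2ccc(Cl)cc2)c1-c1ccc(F)cc1` has not yet been measured in this assay. It differs from compound 1 by chloro in place of hydrogen on an aromatic carbon. Among the compounds with values here, this is the same change as the one from compound 3 to compound 2, made on a different core: the core of compound 1 differs from that of compound 3 by fluoro in place of hydrogen on an aromatic carbon. The measured version of this change gave no readable size. The step that the limit leaves unreadable from compound 1 to compound 4 is expected to be essentially nothing, because compound 1 already sits at the limit of > 680000 nM in this assay, at which 1 of the 3 values shown sits. Compound 4 is therefore expected to give 700000 nM, most likely again as a limit, within an expected range of 200000 nM to 3000000 nM.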

Compound 4, concentration for 50% growth inhibition: > 623000 nM
Compound 4: no number, only a limit; the forecaster's own chance of this, stated with the estimate: 85%; the middle value is on the limit's open side.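

Compound 1 and compound 4 each give only a limit, not a number, and the size of the step between them cannot be read. On these data alone, how strongly any of the four compounds inhibits growth stays open.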